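The compounds below may be only part of what the source reports. "The series", "measured", "known", "first", "only" and "open" are said of these compounds alone.

Measured so far:
compound 1 `Nc1nc(=O)ccn1[C@@H]1O[C@H](COP(=O)(O)O)[C@@H](O)[C@H]1O` — > 100000 nM
compound 2 `COc1nc(=O)ccn1[C@@H]1O[C@H](COP(=O)(O)OP(=O)(O)O)[C@@H](O)[C@H]1O` — 1370 nM

In an in vitro functional assay on 1321-N1 cells for agonist activity at P2Y purinoceptor 6 (Homo sapiens), read by scintillation proximity assay and inositol phosphate accumulation (on this read-out lower numbers stand for an effect already at smaller amounts and higher numbers for an effect only at larger amounts of compound), compound 1 gives > 100000 nM, which is a limit of the assay and not a number. In this assay compound 2 gives 1370 nM. For the measured compounds named here, compound 1 therefore stands at the limit of > 100000 nM in this assay, at which 1 of the 2 values shown sits, and compound 2 is the one measured compound with a number. Going by the values given here, the two differ in more than one place, so no single step between them is drawn; of the pair no more can be said than that one has a number and the other only a limit.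

Compound 3 `O=c1ccn([C@@H]2O[C@H](COP(=O)(O)O)[C@@H](O)[C@H]2O)c(SCCc2ccccc2)n1` is not yet measured. It differs from compound 1 by phenethylsulfanyl in place of amino on an aromatic carbon. Among the compounds with values here, no measured step covers this change, so its size rests on expectation alone. The step of an at least 5.0-fold lower number from compound 1 to compound 3 (0.69 log units; beyond the scatter) is expected to run toward an effect at smaller amounts and to go beyond the usual scatter, though from a limit its true size is not fixed. Compound 3 is expected to give 20000 nM in this assay, within a range from 3000 nM to 150000 nM, with a real chance that the assay again reports only a limit.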

Compound 3, half-maximal effective concentration: > 100000 nM
Compound 3: a limit, no number; the forecaster's own chance of this, stated with the estimate: 40%; middle value at least 5.0-fold (0.69 log units) from the limit.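

Between compound 1 and compound 3 no step can be read, as both results are limits of the assay and not numbers, and both sit at the same one: the limit of > 100000 nM in this assay, at which 2 of the 3 values shown sit.

The compounds shown leave open whether phenethylsulfanyl in place of amino on an aromatic carbon changes the effect at all.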